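The compounds below may be only part of what the source reports. "The series", "measured", "known", "first", "only" and "open" are said of these compounds alone.

Measured in a functional assay on SK-OV-3 cells (Homo sapiens) for cytotoxicity, read by MTT assay, with a stated time of 48 h; on this read-out lower numbers stand for stronger inhibition and higher numbers for weaker inhibition:
compound 1 `O=C(/C=C/c1ccc2c(c1)B(O)OC2)c1ccc(I)cc1` gives 4200 nM
compound 2 `Cc1ccc(C(=O)/C=C/c2ccc3c(c2)B(O)OC3)cc1` gives 3700 nM
compound 3 `Nc1ccc(C(=O)/C=C/c2ccc3c(c2)B(O)OC3)cc1` gives 20200 nM

Compound 3 stands highest of the three numbers in this assay. Its nearest neighbour is compound 1, a step of a 4.8-fold higher number from compound 1 to compound 3 (0.68 log units; beyond the scatter), and the furthest is compound 2, a step of a 5.5-fold higher number from compound 2 to compound 3 (0.74 log units; beyond the scatter). Between compound 1 and compound 2 the step is a 1.1-fold lower number from compound 1 to compound 2 (0.06 log units; within the scatter).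

The next compound is compound 4 `O=C(/C=C/c1ccc2c(c1)B(O)OC2)c1ccc([N+](=O)[O-])cc1`. It differs from compound 3 in one place: nitro in place of amino on an aromatic carbon.

Among the measured compounds shown here, no step in this set brings in a nitro group, so nothing measured speaks directly to what nitro does here. What is measured is that the amino group, in both steps where it enters, raised the number: from compound 1 to compound 3 and from compound 2 to compound 3. The step to compound 4 takes that amino group out again. The expectation is therefore that the number falls back from the level of compound 3, roughly to where compound 1 and compound 2 sit, an expected step of a 4.5-fold lower number from compound 3 to compound 4 (0.65 log units; beyond the scatter). As far as these compounds go, on that basis compound 4 is estimated at 4500 nM in this assay, within a range of 1500 nM to 14000 nM; the uncertainty is wide because nitro itself is untested.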

Compound 4, half-maximal inhibitory concentration: 7900 nM
Compound 4: middle estimate off by 1.8-fold (0.24 log units), on the low side; the measured number falls inside the stated range.
By their numbers in this assay, from the lowest: compounds 2, 1 and 4 (each within the scatter of the next, the first and the last beyond it); then compound 3.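

Replacing amino with nitro on the aromatic carbon para to a large group gives a 2.6-fold lower number from compound 3 to compound 4 (0.41 log units; beyond the scatter) in this assay, so the higher number of compound 3 is not shared by every polar-looking change of this kind of group only in name, and a second nitrogen-bearing group now sits at a different level from amino. Nitro does not line up evenly with the other two groups: the step of a 1.9-fold higher number from compound 1 to compound 4 (0.27 log units; within the scatter) stays within the scatter, while the step of a 2.1-fold higher number from compound 2 to compound 4 (0.33 log units; beyond the scatter) lies just beyond it, even though compound 1 and compound 2 are themselves within the scatter of each other. Amino therefore remains the one group of the four whose steps to all the others are beyond the scatter, and the position accepts iodo, methyl and nitro with numbers that differ far less than any of them differs from amino.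

Nothing available here bears on why these numbers differ. As far as these compounds go, whether a carboxylic acid, a nitrile, a methoxy group or an acylated amine on the same carbon would fall with iodo, methyl and nitro or with amino stays open, as does whether this order carries over to other cell lines.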